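The compounds below may be only part of what the source reports. "The series", "measured", "known", "first", "only" and "open" are said of these compounds alone.

Compounds measured so far:

Compound 1, `Cc1ccc(-c2cc(/N=C3/NC(=O)CS3)cs2)cc1`: > 50000 nM in a functional assay on SW-620 cells (Homo sapiens) for cytotoxicity, read by MTT assay, with a stated time of 72 h; a higher number here means a weaker inhibitor, a lower number a stronger inhibitor 
Compound 2, `O=C1CS/C(=N\c2csc(-c3ccccc3)c2)N1`: > 50000 nM in this assay 
Compound 3, `COc1cccc(N2C(=O)CS/C2=N\c2csc(-c3ccccc3)c2)c1`: "not determined" (no result reported) in this assay 

The value for compound 1 is a limit of this assay, not a number. The value for compound 2 is likewise a limit. For compound 3 no result was reported, so it stands without a number, while the two values beside it both sit at the limit of > 50000 nM in this assay, at which 2 of the 3 values shown sit.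

Compound 4, `COc1cccc(N2C(=O)CS/C2=N\c2csc(-c3ccc(C)cc3)c2)c1`, differs from compound 3 by methyl in place of hydrogen on an aromatic carbon, that is, phenyl to 4-methylphenyl. Among the compounds with values here, the one measured step that touches this same change, a step that the two limits leave unreadable from compound 1 to compound 2, runs the other way and cannot be read, since both ends are limits. So the size and direction of the step from compound 3 to compound 4 in this assay cannot be taken from the measured compounds. Given that the two measured values both lie at the limit, compound 4 is expected to sit near the same limit, estimated at 50000 nM with a range of 20000 nM to 120000 nM.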

Compound 4, half-maximal inhibitory concentration: > 50000 nM
Compound 4: no number, only a limit (the forecaster's own chance of this, stated with the estimate: 80%); the middle value sits exactly at the limit.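

Compound 4 gives only a limit, as compound 1 does, so the step between these two compounds cannot be read in size or direction: the limit of > 50000 nM in this assay, at which 3 of the 4 values shown sit.

The compounds shown leave open whether any change to the shared core would give a measurable number in this assay.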